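Replacing pyrimidin-5-yl with 2,4,6-trifluorophenyl

The source may report more compounds than this note shows. Statements on the series, on what has been measured and on what is new or still open speak of the compounds shown alone.

Values in an ADME assay on LLC-MK2 cells (Macaca mulatta) for cytotoxicity, read by spectrophotometry and crystal violet staining, with a stated time of 4 days (a lower number here means that less compound is tolerated, a higher number that more compound is tolerated), so far

Compound 1 `CC(C)n1ncc2c(C(=O)Nc3ncccn3)cc(-c3cccs3)nc21` gives 75000 nM
Compound 2 `CC(C)n1ncc2c(C(=O)Nc3ccc(F)cc3F)cc(-c3cccs3)nc21` gives > 200000 nM as a limit of the assay
Compound 3 `CC(C)n1ncc2c(C(=O)Nc3cncnc3)cc(-c3cccs3)nc21` gives 20000 nM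

Compound 3 stands lowest of the three in this assay. Its nearest neighbour is compound 1, and the gap is a 3.8-fold lower number from compound 1 to compound 3 (0.57 log units; beyond the scatter). Compound 4 `CC(C)n1ncc2c(C(=O)Nc3c(F)cc(F)cc3F)cc(-c3cccs3)nc21` differs from compound 3 on the amide-type nitrogen, with 2,4,6-trifluorophenyl in place of pyrimidin-5-yl (2,4,6-trifluorophenyl in place of pyrimidin-5-yl on an amide-type nitrogen). For the measured compounds named here, two measured steps bear on this change. One is an at least 10-fold lower number from compound 2 to compound 3 (1.00 log units; beyond the scatter), which runs nearly opposite to the change at hand. The other is an at least 2.6-fold higher number from compound 1 to compound 2 (0.42 log units; beyond the scatter), which also exchanges a pyrimidine ring for 2,4-difluorophenyl. Both point to a higher number when a fluorinated phenyl takes the place of a pyrimidine ring, although neither carries 2,4,6-trifluorophenyl itself. A rise beyond the scatter is therefore expected, and the estimated change is a 7.5-fold higher number from compound 3 to compound 4 (0.88 log units; beyond the scatter). For compound 4 the expected value is 150000 nM, with an estimated range from 50000 nM to 300000 nM.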

Compound 4, half-maximal cytotoxic concentration: > 200000 nM
Compound 4 gave a limit, no number (the forecaster's own chance of this, stated with the estimate: 55%); at least 1.3-fold (0.12 log units) between middle value and limit.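

A second fluorinated phenyl group on the amide-type nitrogen now stands clear of both pyrimidine rings in this assay, with an at least 10-fold higher number from compound 3 to compound 4 (1.00 log units; beyond the scatter) and an at least 2.6-fold higher number from compound 1 to compound 4 (0.42 log units; beyond the scatter). The rise seen earlier with 2,4-difluorophenyl is therefore not confined to that one group, although the two fluorinated compounds end in the same way, each at a limit and not a number: the limit of > 200000 nM in this assay, at which 2 of the 4 values shown sit. The step from compound 2 to compound 4 cannot be read, so this assay gives no size for the added fluoro on the aromatic carbon.

On these data alone, it remains open where an unsubstituted phenyl or a pyridine ring on the same nitrogen would fall in this assay. A phenyl ring carrying an amine or a carboxylic acid in place of fluoro also remains untested among the compounds shown.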